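Chloro for Hydrogen on the Aryl Hydrazone of Compound 3

The source may hold more compounds than are shown below. What is called first, only, known or untested is meant among the compounds shown, and "the series" means these compounds.

Compound 3 `CNc1ncccc1C(=O)N/N=C/c1ccccc1` gives 47.2% in a functional assay on the whole organism (strain Wistar) for inhibition, with Rattus norvegicus as the target, read by paw edema, with a stated time of 2 h, at a dose of 10 mg/kg by the intraperitoneal route; on this read-out lower numbers stand for less inhibition and higher numbers for more inhibition at the one dose given (going by the name of the read-out). Among the three measured compounds it stands second highest: compound 2 `O=C(N/N=C/c1ccc(O)c(O)c1)c1cccnc1Nc1cccc(C(F)(F)F)c1` gives 46.9%, within the scatter of compound 3, while compound 1 `O=C(N/N=C/c1cccc(Cl)c1)c1cccnc1Nc1cccc(C(F)(F)F)c1` gives 63.5%, beyond it. Compound 4 `CNc1ncccc1C(=O)N/N=C/c1cccc(Cl)c1` differs from compound 3 by chloro in place of hydrogen on an aromatic carbon. Among the compounds with values here, no measured step matches this change exactly; the nearest is a number 16.6 percentage points lower from compound 1 to compound 2 (beyond the scatter), where the compound carrying the chloro gave the higher number. On that basis a modest rise in this assay is expected for compound 4, namely a number 7.8 percentage points higher from compound 3 to compound 4 (within the scatter). Compound 4 is therefore estimated at 55%, with a range from 42% to 68%.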

Compound 4, a percentage reported as inhibition, in the whole organism at one dose (the size of the read-out at that dose, not a potency): 61.7%
For compound 4 the middle estimate is 6.7 percentage points below the measured one; the range from low to high includes it.
By their numbers in this assay, from the lowest: compounds 2 and 3 (each within the scatter of the next); then compounds 4 and 1 (each within the scatter of the next).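

The earlier step replaced the whole 3-chlorophenyl with 3,4-dihydroxyphenyl, so it could not separate the chloro from the hydroxyl groups. Here, in this assay, chloro alone in place of hydrogen, meta to a large group, gives a number 14.5 percentage points higher from compound 3 to compound 4 (beyond the scatter). Nothing shown gives a reason for this rise.

From the compounds shown here alone, whether a fluoro, a methoxy or an amine at this place would give a number like that of the chloro remains open. So does whether the chloro would give the same rise on another aromatic carbon of this ring.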